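Piperazine for pyrazole on the shared core: solubility note

The source may hold more compounds than are shown below. What is called first, only, known or untested is meant among the compounds shown, and "the series" means these compounds.

Two compounds of the series have numbers in a physicochemical assay for solubility, read by LC-MS, in phosphate buffer, measured as thermodynamic solubility, with a stated time of 24 h, at pH 7.4; a lower number here means a less soluble compound, a higher number a more soluble compound. Compound 1 `Cn1cc(-c2cnc3[nH]cc(-c4ccccc4C#N)c3c2)cn1` gives 11000 nM in this assay. Compound 2 `N#Cc1cccc(-c2c[nH]c3ncc(-c4cn[nH]c4)cc23)c1` gives 26000 nM in this assay, the higher of the two numbers, and the gap to compound 1 lies beyond the usual scatter of the measurement. Compound 3 `CN1CCN(c2cnc3[nH]cc(-c4cccc(C#N)c4)c3c2)CC1` has not yet been measured in this assay. It differs from compound 2 in one place: 4-methylpiperazin-1-yl in place of 1H-pyrazol-4-yl on an aromatic carbon. Within the data shown here, no measured pair carries this change, so its size is not known from the data. The expected step, a 2.7-fold higher number from compound 2 to compound 3 (0.43 log units; beyond the scatter), is upward and somewhat beyond the scatter, though with wide uncertainty. For compound 3 the estimate in this assay is 70000 nM, with a range from 20000 nM to 250000 nM.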

Compound 3, solubility: 230000 nM
Compound 3: middle estimate off by 3.3-fold (0.52 log units), on the low side; the measured number falls inside the stated range.
By their numbers in this assay, from the lowest: compound 1; then compound 2; then compound 3.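

Among these compounds, compound 1 and compound 2 form no pair differing in one place, so this position had no reading of its own in this assay. The aromatic carbon two atoms from the ring nitrogen now has one: 4-methylpiperazin-1-yl in place of 1H-pyrazol-4-yl gives an 8.8-fold higher number from compound 2 to compound 3 (0.95 log units; beyond the scatter), so the group held at this position can move the number beyond the scatter. The step bundles several differences, a five-membered aromatic ring giving way to a six-membered non-aromatic ring and the hydrogen-bond donor leaving, and no measurement shown bears on which of them carries it.

Open, as far as these compounds go, is whether the step follows the whole 4-methylpiperazin-1-yl ring or its methyl; a piperazine without the methyl, a morpholine or an open-chain amine on the same carbon would separate these. Also open, from the compounds shown here alone, is whether the step holds with the nitrile placed as in compound 1.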